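This account rests on a few compounds, and the source may have more. Where it says the series, first, only, none or still open, it means among the compounds named here.

Measured compounds and their values in a functional assay on HepG2 cells (Homo sapiens) for antiproliferative activity, with a stated time of 72 h; a lower number here means that less compound is needed, a higher number that more compound is needed for the effect:

Compound 1 `COc1ccc(-c2cc(=O)c3c(OC)cc(OC)cc3n2C)cc1` — "not determined" (no result reported)
Compound 2 `COc1ccc(-c2cc(=O)c3c(OC)cc(OC)cc3n2S(=O)(=O)c2ccc(C=O)cc2)cc1` — a limit only, > 34400 nM
Compound 3 `COc1ccc(-c2cc(=O)c3c(OC)cc(OC)cc3n2S(=O)(=O)c2ccc([N+](=O)[O-])cc2)cc1` — a limit only, > 29300 nM
Compound 4 `COc1ccc(-c2cc(=O)c3c(OC)cc(OC)cc3n2S(=O)(=O)c2cccc([N+](=O)[O-])c2)cc1` — not yet measured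

Compound 3 stands at a limit of this assay, > 29300 nM, and not at a number. Compound 2 likewise stands at a limit, > 34400 nM. For compound 1 the entry is "not determined" (no result reported). Among the compounds with values here, the one measured step that touches compound 3, a step that the two limits leave unreadable from compound 2 to compound 3, is therefore unreadable: both ends sit at limits, as the limit of > 29300 nM in this assay, at which 1 of the 3 values shown sits, and the limit of > 34400 nM in this assay, at which 1 of the 3 values shown sits, record, so no size can be assigned to the exchange of formyl for nitro on the aromatic carbon.

The change to compound 4 is 3-nitrophenyl in place of 4-nitrophenyl on a sulfonyl sulfur. Within the data shown here, no measured step bears on a shift of the nitro group from one position of the phenyl ring to another; the only neighbouring step is the unreadable one just named. With compound 3 at a limit and nothing to suggest a move off it, the expectation is that compound 4 also comes out at or near the limit: the estimate for compound 4 is 30000 nM, ranging from 8000 nM to 100000 nM, which as a step means a step that the limit leaves unreadable from compound 3 to compound 4, read as no change beyond the scatter.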

Compound 4, half-maximal effective concentration: > 39600 nM
Compound 4 ended at the assay's limit; the forecaster's own chance of this, stated with the estimate: 75%; middle value at least 1.3-fold (0.12 log units) from the limit.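

In this assay, within the data shown here, compound 2, compound 3 and compound 4 all stand at limits and not at numbers, so no step among them can be read. The compounds shown leave open whether 4-formylphenyl, 4-nitrophenyl and 3-nitrophenyl on the sulfonyl sulfur differ at all in this assay.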